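Phenoxy to 2-oxopyrrolidin-1-yl on the fused core

The compounds below may be only part of what the source reports. "The series", "measured", "known", "first", "only" and "open" are said of these compounds alone.

Going by the values given here, compound 1 `Fc1ccc2c(c1CNc1ncc(Oc3ccccc3)c3nncn13)CCO2` is the more lipophilic of the two measured members. In a physicochemical assay for lipophilicity, using the shake flask method, in phosphate buffer, measured as octanol-water partition, with a stated time of 30 min, at pH 7.4 (on this read-out lower numbers stand for lower lipophilicity and higher numbers for higher lipophilicity), compound 1 gives 3.5, the highest of the two numbers in hand. Compound 2 `Cc1nc(CO)ccc1-c1cnc(NCc2c(F)ccc3c2CCO3)c2cn[nH]c(=O)c12`, built on a different core and carrying a hydroxymethyl group, gives in this assay a value of 2.4, and the gap between compound 2 and compound 1 lies beyond the scatter of this kind of measurement. Among the compounds with values here, no single-point step between measured compounds is available, so nothing is known yet about how one exchange on the core of compound 1 moves the read-out.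

Compound 3 `O=C1CCCN1c1cnc(NCc2c(F)ccc3c2CCO3)n2cnnc12` is the next member, still to be measured in this assay. It differs from compound 1 in one place: 2-oxopyrrolidin-1-yl in place of phenoxy on an aromatic carbon. A six-membered aromatic ring of carbon only thus gives way to a five-membered non-aromatic ring with one hetero atom and a double bond outside aromatic rings. The expected step is downward and well beyond the scatter, namely a number 1.70 log units lower from compound 1 to compound 3 (beyond the scatter). Compound 3 is accordingly estimated at 1.8, with a range from 1.1 to 2.5.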

Compound 3, distribution coefficient: 1.3
Compound 3: middle estimate off by 0.50 log units, on the high side, and the stated range covers the measured number.
By their numbers in this assay, from the lowest: compound 3; then compound 2; then compound 1.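

In this assay, going by these compounds alone, the exchange of phenoxy for 2-oxopyrrolidin-1-yl gives a number 2.20 log units lower from compound 1 to compound 3 (beyond the scatter) and provides the first single-place step, a large one. This position, on an aromatic carbon ortho to a fused ring and para to a large group, is therefore not indifferent to the group it carries, at least for this pair. The step combines several changes: a six-membered aromatic ring of carbon only leaves, while a five-membered non-aromatic ring with 1 hetero atom and a double bond outside aromatic rings enters, and no measurement at hand accounts for the size of the step.

The compounds shown do not separate the loss of the aromatic ring from the arrival of the new ring and its carbonyl, and a single pair cannot show whether the step would hold on another core. Going by these compounds, it also remains open where an amine such as pyrrolidin-1-yl, lacking the carbonyl, or a small ether such as methoxy would fall at this position in this assay.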